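The source may report more compounds than this note shows. Statements on the series, on what has been measured and on what is new or still open speak of the compounds shown alone.

Of the compounds shown here, two with a shared core have been measured in a functional assay on RPMI18226 cells (Homo sapiens) for antiproliferative activity, read by sulforhodamine B assay, with a stated time of 48 h, tested at 10 uM; on this read-out higher numbers stand for more inhibition at the one concentration tested (going by the name of the read-out) and lower numbers for less inhibition. Compound 1 `Cc1ccc(NC(=O)c2c(-c3ccc(Cl)cc3)cc(-c3ccccc3)nc2N)cc1` gives 71% in this assay. Compound 2 `O=C(Nc1ccccc1)c1c(-c2ccc(Cl)cc2)cc(-c2ccccc2)nc1Nc1ccc(Cl)cc1` gives 53%, the lower of the two numbers, and the gap to compound 1 lies beyond the usual scatter of this assay. The two compounds differ in more than one place, so the numbers alone cannot be traced to a single change.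

Compound 3 `Cc1ccc(NC(=O)c2c(-c3ccc(Cl)cc3)cc(-c3ccccc3)nc2Nc2ccc(Cl)cc2)cc1` is not yet measured. It differs from compound 2 in one place: methyl in place of hydrogen on an aromatic carbon. No single step of this kind has been measured here, so there is no shown step to lean on. The expected change from compound 2 to compound 3 in this assay is a number 2 percentage points higher from compound 2 to compound 3 (within the scatter), a step within the scatter and of no settled direction. Compound 3 is expected to give about 55%, between 40% and 70%.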

Compound 3, a percentage reported as inhibition, at one concentration (the size of the read-out at that concentration, not a potency): 58%
Compound 3: the middle estimate sits 3 percentage points below what was measured, within the range that was stated.
By their numbers in this assay, from the lowest: compounds 2 and 3 (each within the scatter of the next); then compound 1.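

Replacing phenylcarbamoyl with (4-methylphenyl)carbamoyl gives a number 5 percentage points higher from compound 2 to compound 3 (within the scatter), so this single methyl, placed para to a large group, does not clearly separate the two compounds in this assay. With that methyl held constant, 4-chlorophenyl in place of hydrogen on the nitrogen gives a number 13 percentage points lower from compound 1 to compound 3 (beyond the scatter), a modest step that can now be read as one change, which the earlier pair of compounds did not allow. Nothing available here accounts for either step.

The compounds shown leave open whether a methoxy group or a carboxylic acid at the same ring position would give a clear step. They also leave open how a simple methyl or a longer chain on the nitrogen would compare with 4-chlorophenyl.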